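This account rests on a few compounds, and the source may have more. Where it says the series, first, only, none or still open, it means among the compounds named here.

Measured compounds, with their values in an assay on isolated protein for binding affinity to cysteinyl leukotriene receptor 1 (Cavia porcellus); a lower number here means a stronger inhibitor, a higher number a weaker inhibitor:
compound 1 `COc1cc(C(=O)NS(=O)(=O)c2ccccc2C)ccc1Cc1cn(C(F)F)c2ccc(NC(=O)OC3CCCC3)cc12` gives 1 nM
compound 2 `COc1cc(C(=O)NS(=O)(=O)c2ccccc2C)ccc1Cc1cn(C(=O)N(C)C)c2ccc(NC(=O)OC3CCCC3)cc12` gives 0.4 nM
compound 3 `COc1cc(C(=O)NS(=O)(=O)c2ccccc2C)ccc1Cc1cn(C(=O)N(c2ccccc2)c2ccccc2)c2ccc(NC(=O)OC3CCCC3)cc12` gives 2 nM

Compound 2 stands lowest of these three numbers. For the measured compounds named here, its nearest neighbour is compound 1, reached through the step of a 2.5-fold lower number from compound 1 to compound 2 (0.40 log units; beyond the scatter), which is the only single-place step among the measured set. Compound 3 lies furthest from compound 2, and the two values show a higher number for compound 3 than for compound 2.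

Compound 4 `COc1cc(C(=O)NS(=O)(=O)c2ccccc2C)ccc1Cc1cn(C(=O)NCCN(C)C)c2ccc(NC(=O)OC3CCCC3)cc12` carries the change ((2-(dimethylamino)ethyl)amino in place of dimethylamino on a carbonyl carbon). Going by the values given here, no measured step covers this change directly. The step of a 2.5-fold lower number from compound 1 to compound 2 (0.40 log units; beyond the scatter) concerns the same aromatic nitrogen and was modest in size, while the values of compound 2 and compound 3 show that a larger group on that carbonyl went with a higher number. Compound 4 is therefore expected to show a modest rise, a 2.5-fold higher number from compound 2 to compound 4 (0.40 log units; beyond the scatter), in this assay. The estimated value for compound 4 is 1 nM, with a range from 0.3 nM to 3 nM.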

Compound 4, half-maximal inhibitory concentration: 0.5 nM
Beside the measured number, compound 4's estimate is 2.0-fold (0.30 log units) above it; the measured number falls inside the stated range.
By their numbers in this assay, from the lowest: compounds 2, 4, 1 and 3 (each within the scatter of the next, the first and the last beyond it).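

In this assay, the carbonyl carbon on the aromatic nitrogen accepts a longer, amine-bearing chain without a change beyond the scatter: a 1.3-fold higher number from compound 2 to compound 4 (0.10 log units; within the scatter). Set against difluoromethyl, the new group gives a 2.0-fold lower number from compound 1 to compound 4 (0.30 log units; within the scatter), whereas the dimethylcarbamoyl group gave a 2.5-fold lower number from compound 1 to compound 2 (0.40 log units; beyond the scatter), yet the two carbamoyl groups cannot be told apart from each other in this assay. No evidence is available to explain why this chain is accepted at this position.

Going by these compounds, what a hydroxyl or a carboxylic acid would do in place of the dimethylamino at the end of the chain stays open, as does the effect of a longer chain. On these data alone, it is also open whether a cyclic amine such as morpholine would keep the number in the same range.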